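Nitrile replacement on the shared core: toxicity note

The source may report more compounds than this note shows. Statements on the series, on what has been measured and on what is new or still open speak of the compounds shown alone.

Values so far in a toxicity assay on CCRF-CEM cells (Homo sapiens) for cytotoxicity; a higher number here means that more compound is tolerated, a lower number that less compound is tolerated:
- compound 1 `CN(C)c1cccc2c1nc(-c1c(F)cccc1F)n2Cc1c(F)cccc1F` gives > 100 uM as a limit
- compound 2 `N#Cc1cccc2c1nc(-c1c(F)cccc1F)n2Cc1c(F)cccc1F` gives 26.7 uM

Within the data shown here, compound 2 at 26.7 uM is the only exact value in this assay so far. The change to compound 3 `N=C(NO)c1cccc2c1nc(-c1c(F)cccc1F)n2Cc1c(F)cccc1F` is a group of 4 heavy atoms (1 carbon, 2 nitrogen, 1 oxygen; no ring) in place of a group of 2 heavy atoms (1 carbon, 1 nitrogen; no ring), on an aromatic carbon on an aromatic carbon. Among the measured compounds shown here, the only measured step bearing on it is an at least 3.7-fold lower number from compound 1 to compound 2 (0.57 log units; beyond the scatter) and it is open-ended. Compound 1 stands at a limit of > 100 uM in this assay, at which 1 of the 2 values shown sits, in that comparison. Here cyano leaves, the group that entered in that step. A modest move to a higher number is expected, a 1.7-fold higher number from compound 2 to compound 3 (0.23 log units; within the scatter) in this assay for this change. Compound 3 is estimated at 45 uM within an expected range of 15 uM to 100 uM for now.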

Compound 3, half-maximal toxic concentration: 23.1 uM
Compound 3: the middle estimate sits 1.9-fold (0.29 log units) above what was measured, within the range that was stated.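

In this assay, the larger group of compound 3 on this aromatic carbon does not separate from the cyano group, despite its added donors and acceptors: a 1.2-fold lower number from compound 2 to compound 3 (0.06 log units; within the scatter). Compound 3 stays apart from the dimethylamino compound, with an at least 4.3-fold lower number from compound 1 to compound 3 (0.63 log units; beyond the scatter). That step remains open-ended, since compound 1 is recorded only as a limit: the limit of > 100 uM in this assay, at which 1 of the 3 values shown sits.

As far as these compounds go, whether a primary amine or a carboxylic acid on this carbon would group with compound 2 and compound 3 or with compound 1 remains open. From the compounds shown here alone, how far compound 1 lies beyond its limit also remains open.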